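The source may report more compounds than this note shows. Statements on the series, on what has been measured and on what is new or still open speak of the compounds shown alone.

Three compounds share one core and differ only in the group attached to the sulfonyl sulfur. Compound 1 `Cc1ccc2[nH]c(C(=O)N[C@H]3CN(S(=O)(=O)c4cccnc4)C[C@@H]3C(=O)NCCN(C)C)cc2c1` gives 8 uL/min in an ADME assay on cells (Hepatocyte, Rattus norvegicus) for metabolic stability; on this read-out higher numbers stand for fast clearance and lower numbers for slow clearance. Compound 2 `Cc1ccc2[nH]c(C(=O)N[C@H]3CN(S(=O)(=O)c4ccnnc4)C[C@@H]3C(=O)NCCN(C)C)cc2c1` gives 2 uL/min in this assay, and the swap on the sulfonyl sulfur between them shows up as a 4.0-fold lower number from compound 1 to compound 2 (0.60 log units; beyond the scatter). Compound 3 `Cc1ccc2[nH]c(C(=O)N[C@H]3CCN(S(=O)(=O)c4ccccc4)C[C@@H]3C(=O)NCCN(C)C)cc2c1` gives 16 uL/min, the highest of the three numbers; its gap to compound 1 falls within the usual scatter, so those two cannot be told apart on this read-out, while its gap to compound 2 lies beyond the scatter.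

Compound 4 `Cc1ccc2[nH]c(C(=O)N[C@H]3CCN(S(=O)(=O)C4CC4)C[C@@H]3C(=O)NCCN(C)C)cc2c1` has not yet been measured. It differs from compound 3 in one place: cyclopropyl in place of phenyl on a sulfonyl sulfur. Among the compounds with values here, the only measured step that bears on this change is the one from compound 1 to compound 2, where one six-membered aromatic ring on the sulfonyl sulfur gave way to another and the number fell modestly. Within the data shown here, no measured step trades an aromatic ring for a three-membered non-aromatic ring, so the direction of the new step is uncertain. On the evidence of that single modest step, a downward step of similar size, a 2.0-fold lower number from compound 3 to compound 4 (0.30 log units; within the scatter), is expected. Compound 4 is therefore estimated at 8 uL/min, with a range from 3 uL/min to 25 uL/min.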

Compound 4, intrinsic clearance in a liver preparation (reported as CLH), per the amount of preparation that the assay uses: 7 uL/min
Beside the measured number, compound 4's estimate is 1.1-fold (0.06 log units) above it; measured number inside the range.
By their numbers in this assay, from the lowest: compound 2; then compounds 4, 1 and 3 (each within the scatter of the next, the first and the last beyond it).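

In this assay, cyclopropyl in place of phenyl on the sulfonyl sulfur gives a 2.3-fold lower number from compound 3 to compound 4 (0.36 log units; beyond the scatter) and so adds something the earlier pair could not show. Within the data shown here, until now the only step at this position exchanged one six-membered aromatic ring for another, whereas here an aromatic ring gives way to a smaller, three-membered non-aromatic ring and the number still falls, by a modest step that lies beyond the scatter, which shows that, for this pair, an aromatic ring on the sulfur is not needed for the lower number. Nothing available explains why the number moves in this direction.

One step with one small ring cannot show whether the fall follows from losing the aromatic ring or from the particular group that enters, and a methyl, an isopropyl or a cyclobutyl group on the sulfonyl sulfur would help to separate those two readings. Going by these compounds, it also remains open whether pyridazin-4-yl, which gave the lowest number so far on the core of compound 1, would give a lower number than cyclopropyl on the core of compound 4.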